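The source may report more compounds than this note shows. Statements on the series, on what has been measured and on what is new or still open speak of the compounds shown alone.

Measured compounds:
Compound 1 `Cc1ccc(NS(=O)(=O)c2ccc(N3CCNC3=O)cc2)cc1`: 480 nM
Compound 2 `Cc1ccc(C)c(NS(=O)(=O)c2ccc(N3CCNC3=O)cc2)c1`: 46 nM
Compound 3 `Cc1ccccc1NS(=O)(=O)c1ccc(N2CCNC2=O)cc1`: 200 nM

Of the compounds shown here, three on a shared core have been tested in a functional assay on HT-29 cells (Homo sapiens) for antiproliferative activity, read by sulforhodamine B assay, with a stated time of 48 h; on this read-out lower numbers stand for stronger inhibition and higher numbers for weaker inhibition. Compound 1 gives the highest number of the three. Compound 3 comes nearest, with a 2.4-fold lower number from compound 1 to compound 3 (0.38 log units; beyond the scatter) after the change to 2-methylphenyl in place of 4-methylphenyl on the sulfonamide nitrogen, and compound 2 lies furthest, with a 10-fold lower number from compound 1 to compound 2 (1.02 log units; beyond the scatter) after the change to 2,5-dimethylphenyl in place of 4-methylphenyl on that nitrogen. Between those two, a 4.3-fold higher number from compound 2 to compound 3 (0.64 log units; beyond the scatter) follows from hydrogen in place of methyl on an aromatic carbon.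

Compound 4 `COc1cccc(NS(=O)(=O)c2ccc(N3CCNC3=O)cc2)c1` has not yet been measured. It differs from compound 1 in one place: 3-methoxyphenyl in place of 4-methylphenyl on a sulfonamide nitrogen. Going by the values given here, no measured compound carries a methoxy group or a 3-methoxyphenyl on the sulfonamide nitrogen, so there is no direct guide. The two steps from compound 1, a 10-fold lower number from compound 1 to compound 2 (1.02 log units; beyond the scatter) and a 2.4-fold lower number from compound 1 to compound 3 (0.38 log units; beyond the scatter), show that each departure from 4-methylphenyl in this small set gave a lower number, leaving compound 1 as the weakest of the three, but neither step involves a methoxy group. The expectation is therefore a small step down, or none beyond the scatter. Compound 4 is expected to give 300 nM in this assay, between 80 nM and 1200 nM, which means an expected 1.6-fold lower number from compound 1 to compound 4 (0.20 log units; within the scatter).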

Compound 4, half-maximal inhibitory concentration: 120 nM
Compound 4: middle estimate off by 2.5-fold (0.40 log units), on the high side; low and high end bracket the measured number.
By their numbers in this assay, from the lowest: compound 2; then compounds 4 and 3 (each within the scatter of the next); then compound 1.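

In this assay, the change to 3-methoxyphenyl on the sulfonamide nitrogen gives a 4.0-fold lower number from compound 1 to compound 4 (0.60 log units; beyond the scatter), so a third departure from 4-methylphenyl also lowers the number, and none of the listed compounds goes against this; the position therefore accepts an aryl group bearing an oxygen-linked substituent, a kind of group the earlier compounds did not include. Compound 4 cannot be separated from the mono-methyl compound 3, with a 1.7-fold lower number from compound 3 to compound 4 (0.22 log units; within the scatter), but it does not reach the 2,5-dimethylphenyl compound, with a 2.6-fold higher number from compound 2 to compound 4 (0.42 log units; beyond the scatter), which leaves compound 2 with the lowest number of the four. No measurement of any property of these groups accompanies these numbers, so the data give no account of why the steps have these sizes.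

The compounds shown leave open whether the lower number of compound 4 depends on the methoxy group itself or on the loss of the 4-methyl group, a question that a plain phenyl, a 3-methylphenyl or a 4-methoxyphenyl on the same nitrogen would help to settle. They also leave open how an amine or a carboxylic acid on this aromatic ring would fare.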